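The compounds below may be only part of what the source reports. "The series", "measured", "known", "first", "only" and "open" are said of these compounds alone.

Measured in an ADME assay on U2OS cells (Homo sapiens) for cytotoxicity; a lower number here means that less compound is tolerated, a higher number that more compound is tolerated:
compound 1 `CC(C)(O)c1cc2c(-c3ccc(C#N)cc3)nccc2[nH]1`: "not determined" (no result reported)
compound 2 `CC(C)(O)c1cc2c(-c3ccc(-c4ccccc4)c(F)c3)nccc2[nH]1`: 9100 nM
compound 3 `Cc1cccc(-c2nccc3[nH]c(C(C)(C)O)cc23)c1`: 121000 nM

Compound 1 has no number in this assay, so it gives no starting value. Compound 4 `Cc1ccc(-c2nccc3[nH]c(C(C)(C)O)cc23)cc1` is the next to be read, and its difference from compound 1 is methyl in place of cyano on an aromatic carbon, para to a large group. The size of this step cannot be stated without a value for compound 1. The expectation rests on compound 3 at 121000 nM more than on compound 2 at 9100 nM, with no step beyond the scatter expected from compound 3. Compound 4 is estimated at 100000 nM, with an expected range of 35000 nM to 280000 nM.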

Compound 4, half-maximal cytotoxic concentration: 38500 nM
For compound 4 the middle estimate is 2.6-fold (0.41 log units) above the measured one; measured number inside the range.
By their numbers in this assay, from the lowest: compound 2; then compound 4; then compound 3.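

No new step can be read for compound 4 against compound 1, compound 2 or compound 3 in this assay. The compounds shown leave open how methyl in place of cyano changes this read-out. Nothing further bears on the result.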